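Acyl Groups Versus Carboxyethyl at the Enamine Nitrogen

The compounds below may be only part of what the source reports. "The series", "measured", "known", "first", "only" and "open" are said of these compounds alone.

Measured so far in a functional assay on CCRF-CEM cells (Homo sapiens); a higher number here means that more compound is tolerated, a lower number that less compound is tolerated:
Compound 1, `CCOC(=O)NC(=O)NC1=CS(=O)(=O)O[C@@]12[C@@H](CO[Si](C)(C)C(C)(C)C)O[C@@H](n1cc(C)c(=O)n(C)c1=O)[C@@H]2O[Si](C)(C)C(C)(C)C`, gives 3000 nM.
Compound 2, `Cc1cn([C@@H]2O[C@H](CO[Si](C)(C)C(C)(C)C)[C@@]3(OS(=O)(=O)C=C3NC(N)=O)[C@H]2O[Si](C)(C)C(C)(C)C)c(=O)n(C)c1=O`, gives 4360 nM.
Compound 3, `Cc1cn([C@@H]2O[C@H](CO[Si](C)(C)C(C)(C)C)[C@@]3(OS(=O)(=O)C=C3NCCC(=O)O)[C@H]2O[Si](C)(C)C(C)(C)C)c(=O)n(C)c1=O`, gives 19400 nM.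

Compound 3 stands at the highest number of the three, above compound 2 by a 4.4-fold higher number from compound 2 to compound 3 (0.65 log units; beyond the scatter) and above compound 1 by a 6.5-fold higher number from compound 1 to compound 3 (0.81 log units; beyond the scatter). Compound 4, `CC(=O)NC1=CS(=O)(=O)O[C@@]12[C@@H](CO[Si](C)(C)C(C)(C)C)O[C@@H](n1cc(C)c(=O)n(C)c1=O)[C@@H]2O[Si](C)(C)C(C)(C)C`, is not yet measured. It differs from compound 3 in one place: acetyl in place of 2-carboxyethyl on an amine nitrogen.

Within the data shown here, two measured steps bear on this change, and both run in the opposite direction. Replacing an acyl-type substituent by 2-carboxyethyl raised the number, as seen in a 6.5-fold higher number from compound 1 to compound 3 (0.81 log units; beyond the scatter) and in a 4.4-fold higher number from compound 2 to compound 3 (0.65 log units; beyond the scatter), while the exchange between the two acyl-type groups in a 1.5-fold higher number from compound 1 to compound 2 (0.16 log units; within the scatter) stayed within the scatter. Compound 4 carries acetyl, an acyl group again, so compound 4 is expected to fall back towards the numbers of compounds 1 and 2, a decrease of about a 4.3-fold lower number from compound 3 to compound 4 (0.63 log units; beyond the scatter) in this assay. Compound 4 is therefore estimated at 4500 nM, with a range from 1500 nM to 13000 nM.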

Compound 4, half-maximal cytotoxic concentration: 25700 nM
For compound 4 the middle estimate is 5.7-fold (0.76 log units) below the measured one, outside the stated range (above it).
By their numbers in this assay, from the lowest: compounds 1 and 2 (each within the scatter of the next); then compounds 3 and 4 (each within the scatter of the next).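

In this assay, acetyl and 2-carboxyethyl on the amine nitrogen cannot be told apart, with a 1.3-fold higher number from compound 3 to compound 4 (0.12 log units; within the scatter), so an acyl group at this nitrogen does not by itself place a compound with compound 1 and compound 2. Among these compounds, the acyl-type groups, which looked alike in the earlier compounds, now divide, with a 5.9-fold higher number from compound 2 to compound 4 (0.77 log units; beyond the scatter) and an 8.6-fold higher number from compound 1 to compound 4 (0.93 log units; beyond the scatter), so what sets them apart here is methyl on the carbonyl carbon in place of amino or (ethoxycarbonyl)amino. Nothing available explains this division.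

Going by these compounds, it remains open whether a longer acyl chain such as propanoyl, or a benzoyl group, would stay with compound 4 or fall with compound 1 and compound 2, and where the free amine would stand. Also open, on these data alone, is whether the carboxylic acid of compound 3 matters at all, which a plain propyl chain would test.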